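Carbonyl swap: 4-methylpiperazin-1-yl to thiomorpholin-4-yl

The source may report more compounds than this note shows. Statements on the series, on what has been measured and on what is new or still open speak of the compounds shown alone.

Among the compounds with values here, in an in vivo functional assay on the whole organism for inhibition, with Rattus norvegicus as the target (on this read-out lower numbers stand for an effect already at smaller amounts and higher numbers for an effect only at larger amounts of compound), compound 1 `CCCCc1nc(C)c(CC(=O)N(CC)CC)c(=O)n1Cc1ccc(-c2ccccc2-c2nnn[nH]2)cc1` gives 0.089 mg/kg as the only number. Compound 2 `CCCCc1nc(C)c(CC(=O)N2CCN(C)CC2)c(=O)n1Cc1ccc(-c2ccccc2-c2nnn[nH]2)cc1` has no number to stand on, and its result in this assay reads "not determined" (no result reported) with nothing to compare. Compound 3 `CCCCc1nc(C)c(CC(=O)N2CCSCC2)c(=O)n1Cc1ccc(-c2ccccc2-c2nnn[nH]2)cc1` carries thiomorpholin-4-yl in place of 4-methylpiperazin-1-yl on a carbonyl carbon. No size of change from compound 2 can be read in this assay, so the expectation leans on compound 1 at 0.089 mg/kg and allows a modest shift upward, little beyond the scatter. The estimated value for compound 3 is 0.15 mg/kg within an expected range of 0.04 mg/kg to 0.5 mg/kg in this series.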

Compound 3, dose for half-maximal effect: 0.038 mg/kg
For compound 3 the middle estimate is 3.9-fold (0.60 log units) above the measured one; measured number below the stated range.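

In this assay, thiomorpholin-4-yl in place of diethylamino on a carbonyl carbon gives a 2.3-fold lower number from compound 1 to compound 3 (0.37 log units; beyond the scatter), so this place accepts a six-membered non-aromatic ring holding sulfur without loss of effect at smaller amounts. The step from compound 2 to compound 3 cannot be read, as compound 2 has no number. Nothing measured here bears on the origin of this gain.

As far as these compounds go, the effect of 4-methylpiperazin-1-yl at this place remains open. Morpholin-4-yl and piperidin-1-yl would show whether the sulfur atom or the ring itself goes with the lower number.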